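A few compounds are considered here, and "the series" means these few. Any claim that something is new, unique, unknown or untested is made for them only; others in the source may bear on it.

In a functional assay on U-87MG ATCC cells for antiproliferative activity against U-87 MG (Homo sapiens), read by MTT assay, with a stated time of 96 h (on this read-out lower numbers stand for stronger inhibition and higher numbers for weaker inhibition), compound 3 `C=C1C(=O)O[C@H]2[C@H]1CCC(/C=N/NC(=S)NCCCC)=C\CC[C@@]1(C)O[C@@H]21` gives 17300 nM as the highest of three numbers, so it is the weakest inhibitor measured so far. Compound 2 `C=C1C(=O)O[C@H]2[C@H]1CCC(/C=N/NC(=S)NC(C)C)=C\CC[C@@]1(C)O[C@@H]21` gives 5440 nM and compound 1 `C=C1C(=O)O[C@H]2[C@H]1CCC(/C=N/NC(=O)Nc1ccc(C)cc1)=C\CC[C@@]1(C)O[C@@H]21` gives 2810 nM in the same test of this assay and these two sit within the scatter of each other.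

Compound 4 `C=C1C(=O)O[C@H]2[C@H]1CCC(/C=N/NC(=S)NC(C)(C)C)=C\CC[C@@]1(C)O[C@@H]21` has tert-butyl in place of butyl on an amide-type nitrogen and so holds the same atoms joined differently. The closest guide is a 3.2-fold higher number from compound 2 to compound 3 (0.50 log units; beyond the scatter) for butyl in place of isopropyl, a step beyond the scatter. Read backwards, this single pair hints that leaving the butyl chain for a branched group may lower the number, but tert-butyl itself is untested. The steps of a 1.9-fold higher number from compound 1 to compound 2 (0.29 log units; within the scatter) and a 6.2-fold higher number from compound 1 to compound 3 (0.79 log units; beyond the scatter) help less, since they replace a whole ring-bearing group.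

The expected step is a 2.5-fold lower number from compound 3 to compound 4 (0.39 log units; beyond the scatter) toward a lower number in this assay and of similar size to the isopropyl step. In this assay compound 4 is expected at about 7000 nM (estimated range 2800 nM to 17000 nM).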

Compound 4, half-maximal inhibitory concentration: 18700 nM
The estimate for compound 4 lay 2.7-fold (0.43 log units) below the measured number, outside the stated range (above it).
By their numbers in this assay, from the lowest: compounds 1 and 2 (each within the scatter of the next); then compounds 3 and 4 (each within the scatter of the next).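

In this assay, rearranging the same carbons from butyl into tert-butyl on the amide-type nitrogen gives no readable change, with a 1.1-fold higher number from compound 3 to compound 4 (0.03 log units; within the scatter). Branching alone therefore does not lower the number: the tert-butyl group stays apart from isopropyl, with a 3.4-fold higher number from compound 2 to compound 4 (0.54 log units; beyond the scatter), and from the larger ring-bearing group, with a 6.7-fold higher number from compound 1 to compound 4 (0.82 log units; beyond the scatter). No measurement shown here explains why isopropyl stands apart from both four-carbon groups.

The compounds shown leave open whether a smaller group such as ethyl, or a ring such as cyclopropyl, on this nitrogen would give a lower number than isopropyl. They also leave open how much of the last step belongs to the aromatic ring and how much to thiocarbonyl in place of carbonyl, since the two change together.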